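Fluoro in place of one chloro in compound 1

A few compounds are considered here, and "the series" means these few. Any claim that something is new, unique, unknown or untested is made for them only; others in the source may bear on it.

In a physicochemical assay for solubility, measured as kinetic solubility, with a stated time of 1 h, at pH 7.4 (a higher number here means a more soluble compound, a lower number a less soluble compound), compound 1 `CC(=O)Nc1nc(-c2ccc(Cl)c(Cl)c2)cs1` gives < 1000 nM, which is a limit of the assay and not a number. Compound 2 `CC(=O)Nc1nc(-c2ccc(Cl)cc2)cs1` gives 1000 nM. Among the compounds with values here, the one measured step, a number no lower from compound 1 to compound 2 (the limit leaves the size open), puts hydrogen in place of chloro on an aromatic carbon. Compound 3 `CC(=O)Nc1nc(-c2ccc(F)c(Cl)c2)cs1` has not yet been measured. It differs from compound 1 by fluoro in place of chloro on an aromatic carbon, ortho to a chloro group. The measured step bears on this change only loosely, since it replaces the other chloro, and with hydrogen, and its size cannot be read. Within the data shown here, no step of known size therefore stands behind the expectation. A small rise in this assay is expected, possibly none beyond the scatter. Among the measured compounds shown here, compound 2 at 1000 nM gives the only number nearby, so the expectation stays close to it. The expected step is a step that the limit leaves unreadable from compound 1 to compound 3. For compound 3 the estimate is 900 nM, with an expected range from 400 nM to 2000 nM, and a result reported only as a limit is also quite possible.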

Compound 3, solubility: 10000 nM
The estimate for compound 3 lay 11-fold (1.05 log units) below the measured number; measured number above the stated range.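

In this assay, fluoro in place of chloro on an aromatic carbon, ortho to a chloro group and para to a group of 9 heavy atoms, gives an at least 10-fold higher number from compound 1 to compound 3 (1.00 log units; beyond the scatter), so exchanging one halogen at this position is enough to produce a step beyond the scatter. The earlier step placed hydrogen on the other chloro-bearing carbon and could not be read for size, whereas this one gives the series its first step with a readable lower bound, and it comes from a change of one heavy atom for one heavy atom with no change in the counted hydrogen-bond donors, acceptors or net charge. Compound 1 gives < 1000 nM, which is a limit of the assay and not a number, so the step has no fixed upper size: the limit of < 1000 nM in this assay, at which 1 of the 3 values shown sits.

The compounds shown leave open whether this step depends on fluoro specifically or would also follow from hydrogen, a methoxy group, a nitrile or an amine at the same position. They also leave open whether fluoro on the other chloro-bearing carbon would give a step of similar size.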